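This account rests on a few compounds, and the source may have more. Where it says the series, first, only, none or still open, it means among the compounds named here.

The three compounds measured here share one core and differ only in the group on one aromatic carbon. Compound 1 `Nc1ccc(S(=O)(=O)N2CCN(c3ncc(C(O)(C(F)(F)F)C(F)(F)F)cc3C#CCCO)CC2)cn1` carries a 4-hydroxybut-1-yn-1-yl group there. In an ADME assay (liver) for metabolic stability, with Liver microsome (Homo sapiens) as the target, using microsomes and NADPH, with a stated time of 30 min, tested at 1 uM (a lower number here means slower removal, a higher number faster removal of the compound), compound 1 gives only a limit, < 14 mL.min-1.g-1, as captured by the limit of < 14 mL.min-1.g-1 in this assay, at which 1 of the 3 values shown sits. Compound 2 `CCn1cc(-c2cc(C(O)(C(F)(F)F)C(F)(F)F)cnc2N2CCN(S(=O)(=O)c3ccc(N)nc3)CC2)cn1` carries a 1-ethyl-1H-pyrazol-4-yl group, and in this assay compound 2 gives 20 mL.min-1.g-1. Compound 3 `Nc1ccc(S(=O)(=O)N2CCN(c3ncc(C(O)(C(F)(F)F)C(F)(F)F)cc3-c3ccccc3O)CC2)cn1` carries a 2-hydroxyphenyl group, and in this assay compound 3 gives 22 mL.min-1.g-1. Of the two numbers it is the higher, but the gap to compound 2 lies within the scatter: a 1.1-fold higher number from compound 2 to compound 3 (0.04 log units; within the scatter). The steps from the limit of compound 1, an at least 1.4-fold higher number from compound 1 to compound 2 (0.15 log units; that floor lies within the scatter) and an at least 1.5-fold higher number from compound 1 to compound 3 (0.19 log units; that floor lies within the scatter), have floors that also lie within the scatter.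

Compound 4 `COc1cncc(-c2cc(C(O)(C(F)(F)F)C(F)(F)F)cnc2N2CCN(S(=O)(=O)c3ccc(N)nc3)CC2)c1` is not yet measured. It differs from compound 3 in one place: 5-methoxypyridin-3-yl in place of 2-hydroxyphenyl on an aromatic carbon. Every measured step swaps the group on that same aromatic carbon, and none of them moved the number beyond the scatter, so no direction can be read from them. The step expected is no change at the digits printed from compound 3 to compound 4 (within the scatter), nothing beyond the scatter. The estimate for compound 4 in this assay is 22 mL.min-1.g-1, within a range from 10 mL.min-1.g-1 to 48 mL.min-1.g-1.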

Compound 4, intrinsic clearance in microsomes: 44 mL.min-1.g-1
Compound 4: the middle estimate sits 2.0-fold (0.30 log units) below what was measured, and the stated range covers the measured number.
By their numbers in this assay, from the lowest: compounds 2, 3 and 4 (each within the scatter of the next, the first and the last beyond it). At a limit, below all of these: compound 1.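

Swapping in 5-methoxypyridin-3-yl gives the first step at this position, on an aromatic carbon of a six-membered aromatic ring with 1 nitrogen, that clears the scatter between two measured numbers in this assay: a 2.2-fold higher number from compound 2 to compound 4 (0.34 log units; beyond the scatter). That step is modest, and the change against the closest comparison does not clear the scatter, with a 2.0-fold higher number from compound 3 to compound 4 (0.30 log units; within the scatter), so the group on this carbon can move the number only in part of the set shown. The step from the limit also clears the scatter, unlike the earlier floors, with an at least 3.1-fold higher number from compound 1 to compound 4 (0.49 log units; beyond the scatter), but compound 1 stands only at a limit: the limit of < 14 mL.min-1.g-1 in this assay, at which 1 of the 4 values shown sits.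

The compounds shown do not separate the ring nitrogen of 5-methoxypyridin-3-yl from its methoxy group, so it stays open whether a 3-pyridyl group or a 3-methoxyphenyl group would fall nearer compound 3 or compound 4 in this assay. From the compounds shown here alone, it also stays open how an amine or a carboxylic acid on the same carbon would read there, and whether the lower numbers of compound 2 and compound 3 would hold with either.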